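The compounds below may be only part of what the source reports. "The series", "measured", "known", "first", "only" and "open" are said of these compounds alone.

Readings in a physicochemical assay for solubility, at pH 1.1; on this read-out lower numbers stand for lower solubility and higher numbers for higher solubility:

- compound 1 `Cc1cc(CN(CC2CCCCC2)C(CC(=O)O)c2ccc(Cl)cc2)ccc1OCCN1C(=O)CCC1=O`: 3000000 nM
- compound 2 `CCCCN(Cc1ccc(OCCn2c(=O)ccn(C)c2=O)c(OC)c1)C(CC(=O)O)c1ccc(Cl)cc1`: 3000000 nM
- compound 3 `COc1cc(CN(CC(C)C)C(CC(=O)O)c2ccc3c(c2)CCO3)ccc1OCCN1C(=O)CCC1=O`: 3000000 nM

Compound 3 stands at 3000000 nM, level with compound 1 and compound 2 at the digits shown. The measured compounds show no spread, and nothing among them separates one structural feature from another.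

The next compound to be read is compound 4 `COc1cc(CN(CC(C)C)C(CC(=O)O)c2ccc(Cl)c(Cl)c2)ccc1OCCN1C(=O)CCC1=O`. It follows from compound 3 by a single change, the entry of a 3,4-dichlorophenyl: a group of 8 heavy atoms (6 carbon, 2 chlorine; one six-membered aromatic ring of carbon only) in place of a group of 9 heavy atoms (8 carbon, 1 oxygen; one five-membered non-aromatic ring with 1 hetero atom, one six-membered aromatic ring of carbon only), on a saturated chain carbon bound to an amine nitrogen and a saturated chain carbon.

Within the data shown here, no measured pair differing in one place is available, so the size of this change in this assay has no direct precedent. Among the measured compounds shown here, the only guidance is indirect. Set against compound 3, from which it differs in several places, compound 1 reads 3000000 nM. Compound 2, which also differs in several places, reads 3000000 nM. On that showing, no change beyond the scatter is expected in either direction, though a modest fall cannot be excluded. The step expected is a 1.1-fold lower number from compound 3 to compound 4 (0.03 log units; within the scatter). Compound 4 is estimated at 2800000 nM, with an expected range of 1000000 nM to 3200000 nM.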

Compound 4, solubility: 3000000 nM
For compound 4 the middle estimate is 1.1-fold (0.03 log units) below the measured one, and the stated range covers the measured number.
By their numbers in this assay, from the lowest: compounds 1, 2, 3 and 4 (each within the scatter of the next).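

Working notes on the series: in this assay, the first comparison that differs in one place gives no change at the digits printed from compound 3 to compound 4 (within the scatter). On a saturated chain carbon bound to an amine nitrogen and a saturated chain carbon, 3,4-dichlorophenyl can therefore take the place of the group of 9 heavy atoms, which carries a five-membered non-aromatic ring with 1 hetero atom, with the reading staying within the scatter; the exchange removes that ring and its 1 hydrogen-bond acceptor. The earlier compounds could offer only indirect guidance, since they differ from one another in several places, and no measured property is available to account for this result.

From the compounds shown here alone, whether a ring of another kind at this position, such as a pyridine or an aminophenyl, or a phenyl bearing a carboxylic acid, would separate from compound 3 and compound 4 remains open. This single step also says nothing about changes elsewhere on the shared core, such as a longer chain on the amine nitrogen, so the behaviour of those places in this assay remains unresolved.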